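This account rests on a few compounds, and the source may have more. Where it says the series, first, only, none or still open, it means among the compounds named here.

In a functional assay on HL-60 cells (Homo sapiens) for inhibition, read by CCK-8 assay, with a stated time of 48 h, tested at 20 uM (a higher number here means more inhibition of growth at the concentration tested, a lower number less inhibition of growth), three compounds have been measured so far. Compound 1 `N#C/C(=C\c1ccccc1OS(=O)(=O)c1ccc([N+](=O)[O-])cc1)C(=O)Nc1nnc(-c2cccs2)s1` gives 23%, compound 2 `Cc1nnc(NC(=O)/C(C#N)=C/c2cccc(OS(C)(=O)=O)c2)s1` gives 20%, and compound 3 `Cc1ccc(S(=O)(=O)Oc2cccc(/C=C(\C#N)C(=O)Nc3nnc(C)s3)c2)cc1` stands highest at 71%, clear of both others. Going by the values given here, the only measured step between close relatives is a number 51 percentage points higher from compound 2 to compound 3 (beyond the scatter), a large one, with 4-methylphenyl in place of methyl on a sulfonyl sulfur.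

Compound 4 `COc1ccccc1-c1nnc(NC(=O)/C(C#N)=C/c2cccc(OS(=O)(=O)c3ccc(C)cc3)c2)s1` keeps that 4-methylphenyl group and changes a different place: 2-methoxyphenyl in place of methyl on an aromatic carbon. In words, this is 2-methoxyphenyl in place of methyl on an aromatic carbon. The large step lies elsewhere in the molecule, so it gives no direct guide to this change. Compound 1 also bears a ring on that carbon, but it differs from compound 3 in other places too, so its low number settles nothing.

With compound 3 already at 71%, a moderate fall is the more likely outcome, though this is weakly supported. The estimated change is a number 13 percentage points lower from compound 3 to compound 4 (beyond the scatter). For compound 4 the expected value is 58%, with an estimated range from 30% to 85%.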

Compound 4, percent growth inhibition at one concentration: 73%
Compound 4: middle estimate off by 15 percentage points, on the low side; the range from low to high includes it.
By their numbers in this assay, from the lowest: compounds 2 and 1 (each within the scatter of the next); then compounds 3 and 4 (each within the scatter of the next).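

In this assay the move from methyl to 2-methoxyphenyl gives a number 2 percentage points higher from compound 3 to compound 4 (within the scatter) and so leaves no readable difference between the two groups. Going by these compounds alone, the earlier step showed only that the group on the sulfonyl sulfur matters; this one shows that, with 4-methylphenyl kept there, the aromatic carbon of the five-membered ring can carry a whole extra aromatic ring and a methoxy group with growth inhibition retained at the concentration tested. No measurement offered here explains why the two groups read alike.

On these data alone, whether this tolerance extends to a plain phenyl, an amine or a carboxylic acid on the same carbon remains open. As far as these compounds go, it is also open whether 2-methoxyphenyl would give the same reading with methyl rather than 4-methylphenyl on the sulfonyl sulfur.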